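Methoxy addition to compound 2: working notes

This account rests on a few compounds, and the source may have more. Where it says the series, first, only, none or still open, it means among the compounds named here.

Measured in a functional assay on T98G cells (Homo sapiens) for inhibition, read by colorimetric assay and MTT assay, with a stated time of 72 h; on this read-out lower numbers stand for stronger inhibition and higher numbers for weaker inhibition:
- compound 1 `Cn1c2cnc1OCCCCCCCCCCOc1cc3ccccc3cc1-2` (22000 nM)
- compound 2 `C=CCCCCOc1ccccc1-c1cnc(OCCC=C)n1C` (29000 nM)
- compound 3 `COc1ccc(C)cc1-c1cnc(OCCCCc2ccccc2)n1C` (44000 nM)

Compound 2 (29000 nM) stands within the scatter of both compound 1 and compound 3, so the numbers place it in no clear order against either neighbour. The next compound to consider is compound 4 `C=CCCCCOc1ccc(OC)cc1-c1cnc(OCCC=C)n1C`, which differs from compound 2 by one change: methoxy in place of hydrogen on an aromatic carbon. In words, this is methoxy in place of hydrogen on an aromatic carbon, para to a (hex-5-en-1-yl)oxy group.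

Among the measured compounds shown here, no two measured compounds differ in one place only, and the data therefore give no direct precedent for this change. Compound 3 also carries a methoxy group and gives (44000 nM), a value within the scatter of compound 2, although its structure differs in other places too. This is weak support, resting on a single compound. In this assay no step beyond the scatter is expected, and neither direction is favoured. The estimated change is small: a 1.0-fold higher number from compound 2 to compound 4 (0.01 log units; within the scatter) (an expectation only). For compound 4 the expected value is 30000 nM (estimated range 14000 nM to 60000 nM).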

Compound 4, half-maximal inhibitory concentration: 74000 nM
Compound 4: the middle estimate sits 2.5-fold (0.39 log units) below what was measured; measured number outside the range, above it.
By their numbers in this assay, from the lowest: compounds 1, 2, 3 and 4 (each within the scatter of the next, the first and the last beyond it).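

Methoxy in place of hydrogen on an aromatic carbon, para to a (hex-5-en-1-yl)oxy group, gives in this assay a step beyond the scatter, a 2.6-fold higher number from compound 2 to compound 4 (0.41 log units; beyond the scatter), and this is the first comparison in the series between two compounds that differ in one place only. The position is therefore not neutral to this change, and the direction is towards weaker inhibition, although the step is modest and rests on this single pair. Nothing available on these compounds bears on what lies behind the step, so the result stands as an observation without an explanation.

As far as these compounds go, it remains open whether the step belongs to methoxy itself or would also appear with another group at this position, such as fluorine, a hydroxyl, an amine or a longer ethoxy or propoxy chain. From the compounds shown here alone, it also remains open whether methoxy would give a step of similar size and direction at the other carbons of this ring, or on the shared core with the chains of compound 2 replaced.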